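Cyclohexyl for Cyclopentyl on a Carbamate Nitrogen

The source may hold more compounds than are shown below. What is called first, only, known or untested is meant among the compounds shown, and "the series" means these compounds.

Compound 1 `O=C(NC1CCCCC1)Oc1ccc(C2=NCCS2)cc1` gives 100 nM in an assay on cell membranes (strain Wistar) for inhibition of Fatty-acid amide hydrolase 1 (Rattus norvegicus), read by scintillation counting; a higher number here means a weaker inhibitor, a lower number a stronger inhibitor.
Compound 2 `O=C(NC1CCCC1)Oc1ccc(-c2csnn2)cc1` gives 20 nM in this assay.

Of the two measured compounds, compound 2 has the lower number in this assay, and its gap to compound 1 lies beyond the usual scatter of repeated measurements. Compound 3 `O=C(NC1CCCCC1)Oc1ccc(-c2csnn2)cc1` differs from compound 2 in one place: cyclohexyl in place of cyclopentyl on an amide-type nitrogen. Among the measured compounds shown here, no measured pair isolates this single change, so its size is not known from the data. The change is expected to move the number only a little, with the step of a 1.3-fold higher number from compound 2 to compound 3 (0.10 log units; within the scatter) staying within the scatter. Compound 3 is accordingly estimated at 25 nM, in the range 8 nM to 80 nM.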

Compound 3, half-maximal inhibitory concentration: 21 nM
Estimate against measurement, compound 3: 1.2-fold (0.08 log units) above, within the range that was stated.
By their numbers in this assay, from the lowest: compounds 2 and 3 (each within the scatter of the next); then compound 1.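

In this assay, cyclohexyl in place of cyclopentyl on the amide-type nitrogen gives a 1.1-fold higher number from compound 2 to compound 3 (0.02 log units; within the scatter), so the two rings cannot be told apart at this position. Keeping cyclohexyl fixed also isolates a second change, a five-membered aromatic ring with 3 hetero atoms in place of a five-membered non-aromatic ring with 2 hetero atoms on an aromatic carbon, which gives a 4.8-fold lower number from compound 1 to compound 3 (0.68 log units; beyond the scatter). No measurement shown here offers an explanation for either step. From the compounds shown here alone, whether cyclobutyl, phenyl or an open hexyl chain on the same nitrogen would give a similar number remains open.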